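The source may report more compounds than this note shows. Statements on the series, on what has been measured and on what is new or still open speak of the compounds shown alone.

Measured so far:
- compound 1, `Cc1ccsc1-c1ccc(C(=O)Nc2c(C)cc(CO)cc2C)o1`: "not active" (no number reported)
- compound 2, `Cc1cc(CN)cc(C)c1NC(=O)c1ccc(-c2cc(Cl)ccc2Cl)o1`: 90%
- compound 3, `Cc1cc(OCCO)cc(C)c1NC(=O)c1ccc(-c2cc(Cl)ccc2Cl)o1`: 60%

In an assay on isolated protein for inhibition of sphingosine 1-phosphate receptor 5 (Homo sapiens), tested at 25 uM (on this read-out lower numbers stand for less inhibition and higher numbers for more inhibition at the one concentration tested (going by the name of the read-out)), compound 1 gives "not active" (no number reported); no single number stands for it, only the statement that it did not inhibit. Compound 2 and compound 3 share a different aryl group on the furan and carry a substituent on the same aromatic carbon that compound 1 carries hydroxymethyl. In this assay, within the data shown here, compound 2 gives 90% and compound 3 gives 60%; the one step in hand, a number 30 percentage points lower from compound 2 to compound 3 (beyond the scatter), shows that the group at this position can shift the read-out by a modest amount.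

Compound 4, `Cc1ccsc1-c1ccc(C(=O)Nc2c(C)cccc2C)o1`, is compound 1 with hydrogen in place of hydroxymethyl on an aromatic carbon. Among the measured compounds shown here, no measured step removes a group at this position outright, so the step from compound 1 to compound 4 cannot be sized from the data; the pair of compound 2 and compound 3 says only that the substituent there matters by a modest margin. Compound 1 starts from no inhibition, so little room exists for a drop, and nothing in hand points to a rise beyond the scatter. Compound 4 is therefore expected to give about 10% in this assay, with a range of 0% to 40%, and the expected step is none beyond the scatter.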

Compound 4, a percentage reported as inhibition, at one concentration (the size of the read-out at that concentration, not a potency): 40%
Compound 4: middle estimate off by 30 percentage points, on the low side; the measured number falls inside the stated range.
By their numbers in this assay, from the lowest: compound 4; then compound 3; then compound 2.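

Among these compounds, compound 1 carries no single number in this assay, so no step from compound 1 to compound 4 can be read. Nothing in hand accounts for the value of compound 4. The compounds shown leave open what hydrogen at this position gives on the core shared by compound 2 and compound 3.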